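The source may report more compounds than this note shows. Statements on the series, on what has been measured and on what is new or still open speak of the compounds shown alone.

Compounds measured in a functional assay on HEK293 cells for agonist activity at G-protein coupled receptor 39 (Homo sapiens), read by scintillation proximity assay and inositol phosphate accumulation, with a stated time of 75 min; on this read-out lower numbers stand for an effect already at smaller amounts and higher numbers for an effect only at larger amounts of compound:

compound 1 `Cc1nn(-c2ncnc3nc[nH]c23)c2c1C(OCc1ccccc1C#N)CC(=O)N2` gives 127 nM
compound 2 `Cc1nn(-c2ncnc3nc[nH]c23)c2c1C(OCCn1nccc1C)CC(=O)N2` gives 1620 nM
compound 3 `Cc1nn(-c2ncnc3nc[nH]c23)c2c1C(NC(=O)c1ccccc1)CC(=O)N2` gives 158 nM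

Compound 1 stands lowest of the three numbers; compound 3 lies within the scatter of it, while compound 2 lies well beyond. The new compound 4 `Cc1nn(-c2ncnc3nc[nH]c23)c2c1C(OC(=O)c1ccc(F)cc1)CC(=O)N2` differs from compound 1 by (4-fluorophenyl)carbonyl in place of 2-cyanobenzyl on an oxygen on a saturated carbon

Going by the values given here, two measured steps bear on this change. The step of a 13-fold higher number from compound 1 to compound 2 (1.11 log units; beyond the scatter) shows that a large shift appears when the six-membered aromatic ring of carbon only gives way to a five-membered aromatic ring with 2 hetero atoms. The step of a 1.2-fold higher number from compound 1 to compound 3 (0.09 log units; within the scatter) shows that a group built from a carbonyl and a six-membered aromatic ring of carbon only, on the saturated ring carbon, keeps the number close to that of compound 1; the step of a 10-fold lower number from compound 2 to compound 3 (1.01 log units; beyond the scatter) points the same way. Compound 4 keeps a six-membered aromatic ring of carbon only and adds a carbonyl, so compound 4 is expected to give a number near compound 1, with a 2.0-fold higher number from compound 1 to compound 4 (0.29 log units; within the scatter) expected to lie within or only slightly beyond the scatter. Compound 4 is therefore estimated at 250 nM, in the range 80 nM to 800 nM.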

Compound 4, half-maximal effective concentration: 245 nM
Compound 4: the middle estimate sits 1.0-fold (0.01 log units) above what was measured; the range from low to high includes it.
By their numbers in this assay, from the lowest: compounds 1, 3 and 4 (each within the scatter of the next); then compound 2.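

Compound 4 shows that in this assay a carbonyl can stand directly on the oxygen on the saturated carbon without moving the number out of the scatter, either against the 2-cyanobenzyl ether (a 1.9-fold higher number from compound 1 to compound 4 (0.29 log units; within the scatter)) or against the benzamido group (a 1.6-fold higher number from compound 3 to compound 4 (0.19 log units; within the scatter)). It also gives the pyrazole-bearing compound a third comparison, and the gap remains beyond the scatter (a 6.6-fold lower number from compound 2 to compound 4 (0.82 log units; beyond the scatter)), so among these four compounds only compound 2 stands apart, and it alone lacks the six-membered aromatic ring of carbon only. Nothing given here accounts for these differences.

The compounds shown leave open what the fluorine and the nitrile each contribute apart from the rest of their groups. Also open, as far as these compounds go, is how a carboxylic acid or an amine on the aromatic ring, or a longer chain leading to that ring, would read in this assay.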